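Piperidine nitrogen substituent: amide to urea on the naphthalene sulfonamide core

The source may report more compounds than this note shows. Statements on the series, on what has been measured and on what is new or still open speak of the compounds shown alone.

Working notes on the series. Compound 1 `CCN(CC)S(=O)(=O)c1ccc(NC(=O)c2ccccc2)c2ccccc12` reaches only a limit in an assay on L1.2 cells for binding affinity to C-C chemokine receptor type 8 (Homo sapiens); on this read-out lower numbers stand for stronger inhibition and higher numbers for weaker inhibition: compound 1 gives > 30000 nM, which is a limit of the assay rather than a number. Compound 2 `CCOC(=O)N1CCC(NS(=O)(=O)c2ccc(NCCCc3ccccc3)c3ccccc23)CC1` gives 32.1 nM in this assay. Going by the values given here, compound 3 `Cc1ccccc1C(=O)Nc1ccc(S(=O)(=O)NC2CCN(C(=O)CCN)CC2)c2ccccc12` gives 11.3 nM in this assay, the lowest of the two numbers known, with compound 2 the nearest at a higher value beyond the scatter. The remaining entry belongs to compound 1, whose value is a limit of the assay (the limit of > 30000 nM in this assay, at which 1 of the 3 values shown sits).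

Compound 4 `Cc1ccccc1C(=O)Nc1ccc(S(=O)(=O)NC2CCN(C(=O)N(C)C)CC2)c2ccccc12` differs from compound 3 in one place: dimethylamino in place of 2-aminoethyl on a carbonyl carbon. Among the compounds with values here, no step between measured compounds tracks this change, so the size must be judged from the neighbours. Compound 2 carries a different group on the amide-type nitrogen in the ring and gives 32.1 nM, which suggests the position accepts variation without a large penalty. The step from compound 3 to compound 4 in this assay is therefore expected to be small, if anything a slight weakening, and may fall within the scatter: a 1.8-fold higher number from compound 3 to compound 4 (0.25 log units; within the scatter). Compound 4 is estimated at 20 nM in this assay, with a likely range from 6 nM to 70 nM.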

Compound 4, inhibition constant: 1.6 nM
Compound 4: the middle estimate sits 13-fold (1.10 log units) above what was measured; measured number outside the range, below it.
By their numbers in this assay, from the lowest: compound 4; then compound 3; then compound 2. At a limit, above all of these: compound 1.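

In this assay, dimethylamino in place of 2-aminoethyl on a carbonyl carbon gives a 7.1-fold lower number from compound 3 to compound 4 (0.85 log units; beyond the scatter), so this place on the piperidine nitrogen substituent responds clearly to a change that adds no atoms and removes none. The two groups hold the same atoms, joined differently, and the hydrogen-bond donor and acceptor counted on 2-aminoethyl are absent from dimethylamino, so neither is needed for a low number in this pair. The compounds shown give no measurement that explains the size of this step.

With a single matched pair at this place, the step cannot be assigned either to the nitrogen now bonded directly to the carbonyl carbon or to the loss of the 2-aminoethyl amine, and a methylamino group or a simple ethyl chain on the same carbonyl carbon would separate the two readings. As far as these compounds go, how much room the place offers also remains open, since the pair says nothing about a larger diethylamino group or a longer 3-aminopropyl chain.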